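The source may report more compounds than this note shows. Statements on the series, on what has been measured and on what is new or still open speak of the compounds shown alone.

Compounds measured so far, with their values in an assay on frontal cortex for binding affinity to Adrenergic receptor alpha-1 (Rattus norvegicus), read by radioligand binding; a higher number here means a weaker inhibitor, a lower number a stronger inhibitor:

compound 1, `COc1ccccc1N1CCN(CCCCNC(=O)c2ccc([N+](=O)[O-])cc2)CC1`: 14 nM
compound 2, `COc1ccccc1N1CCN(CCCCNC(=O)CCCc2ccccc2)CC1`: 84 nM
compound 3, `CCCCC(=O)NCCCCN1CCN(c2ccccc2OC)CC1`: 84 nM

Compound 3 stands level with compound 2 at the digits given, and together they hold the highest values of the three; compound 1 lies furthest away, with a 6.0-fold higher number from compound 1 to compound 3 (0.78 log units; beyond the scatter) separating them. The other steps read a 6.0-fold higher number from compound 1 to compound 2 (0.78 log units; beyond the scatter) and no change at the digits printed from compound 2 to compound 3 (within the scatter).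

Compound 4, `COc1ccccc1N1CCN(CCCCNC(=O)C(C)(C)C)CC1`, has not been measured. It differs from compound 3 by tert-butyl in place of butyl on a carbonyl carbon. Going by the values given here, none of the measured steps alters the branching of a saturated group on the carbonyl carbon, so no step bears on this change directly. The closest point of reference is the step from compound 2 to compound 3, where a phenyl on the chain gave way to methyl without a change beyond the scatter; the two large steps, from compound 1 to compound 2 and from compound 1 to compound 3, both involved losing the 4-nitrophenyl, which compound 3 has already lost. A step of no more than the scatter is therefore expected for a 1.2-fold higher number from compound 3 to compound 4 (0.08 log units; within the scatter). Compound 4 is estimated at 100 nM, with a range from 40 nM to 250 nM.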

Compound 4, inhibition constant: 74 nM
The estimate for compound 4 lay 1.4-fold (0.13 log units) above the measured number; the measured number falls inside the stated range.
By their numbers in this assay, from the lowest: compound 1; then compounds 4, 2 and 3 (each within the scatter of the next).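

In this assay, going by these compounds alone, the branching of a saturated group on a carbonyl carbon can now be read for the first time: with the same count of carbon atoms, tert-butyl in place of butyl gives a 1.1-fold lower number from compound 3 to compound 4 (0.06 log units; within the scatter) and leaves this position as insensitive to that change as the earlier steps among non-aromatic and chain-linked groups suggested. The comparison with the longer, ring-bearing group gives a 1.1-fold lower number from compound 2 to compound 4 (0.06 log units; within the scatter) so that compound 2, compound 3 and compound 4 sit together whether the group on the carbonyl carbon is straight, branched or carries a phenyl along its chain, while 4-nitrophenyl still stands apart with a 5.3-fold higher number from compound 1 to compound 4 (0.72 log units; beyond the scatter) and compound 1 remains the strongest inhibitor of the four. No measurement shown here gives a reason for this pattern.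

The compounds shown leave open whether the gap to compound 1 goes with the nitro group or with an aromatic ring standing on the carbonyl carbon itself. An unsubstituted phenyl, a 4-aminophenyl or a 4-methoxyphenyl on that carbon would separate the two, and a cyclohexyl would extend the saturated series.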